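Substituent exchange on the shared core and agonist efficacy

The compounds below may be only part of what the source reports. "The series", "measured", "known", "first", "only" and "open" are said of these compounds alone.

Compound 1 `CC(C)(C)[C@H](C(=O)Nc1ncc(C(F)(F)F)s1)c1ccc(Cl)cc1` is the reference point of the pair measured so far: in a functional assay on CHO cells for agonist activity at Free fatty acid receptor 2 (Homo sapiens), read by cAMP accumulation (a lower number here means a smaller maximal response, a higher number a larger maximal response), compound 1 gives 95%. Compound 2 `CN1CCN(c2cnc(NC(=O)[C@H](c3ccc(Cl)cc3)C(C)(C)C)s2)CC1` carries 4-methylpiperazin-1-yl in place of trifluoromethyl on an aromatic carbon, and in this assay compound 2 gives 113%. The step of a number 18 percentage points higher from compound 1 to compound 2 (beyond the scatter) is the only one available. On these two numbers compound 2 stands highest, with compound 1 as its nearest neighbour at a lower value beyond the scatter.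

Compound 3 `CC(C)(C)[C@H](C(=O)Nc1ncc(C(O)(C(F)(F)F)C(F)(F)F)s1)c1ccc(Cl)cc1` is not yet measured. The change from compound 2 to compound 3 is 2,2,2-trifluoro-1-hydroxy-1-(trifluoromethyl)ethyl in place of 4-methylpiperazin-1-yl on an aromatic carbon. Going by the values given here, the single step that bears on it is the one from compound 1 to compound 2, in which a fluorinated group gave way to 4-methylpiperazin-1-yl and the efficacy rose modestly. Compound 3 reverses that direction, reintroducing a fluorine-bearing group of larger size, so a modest fall, of a size comparable to a number 18 percentage points higher from compound 1 to compound 2 (beyond the scatter) but opposite in sign, is expected; the series is too small to say whether the fall will be smaller or larger.

The value of compound 3 in this assay is expected at 100%, within 85% to 115%. Compound 3 is therefore expected to give a number 13 percentage points lower from compound 2 to compound 3 (beyond the scatter).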

Compound 3, largest response reached (reported as efficacy), in percent of the reference or control that the assay uses: 113%
Beside the measured number, compound 3's estimate is 13 percentage points below it; measured number inside the range.
By their numbers in this assay, from the lowest: compound 1; then compounds 2 and 3 (each within the scatter of the next).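

In this assay, 2,2,2-trifluoro-1-hydroxy-1-(trifluoromethyl)ethyl in place of 4-methylpiperazin-1-yl on the aromatic carbon next to the ring sulfur gives no change at the digits printed from compound 2 to compound 3 (within the scatter), so two substituents that share neither a ring nor their hetero atoms read alike at this position. Set against trifluoromethyl, the same group gives a number 18 percentage points higher from compound 1 to compound 3 (beyond the scatter), which shows that a fluorine-bearing group at this position does not in itself go with the lower number of compound 1; compound 3 goes against any such reading. No available evidence bears on why these two different groups read alike in this assay.

The compounds shown do not separate the contribution of the hydroxyl from that of the two trifluoromethyl groups in compound 3, a question that the matching group with hydrogen in place of the hydroxyl would address. They also leave open whether a smaller open-chain amine such as dimethylamino, or a carboxylic acid, on the same carbon would read with compound 1 or with compounds 2 and 3.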